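The source may report more compounds than this note shows. Statements on the series, on what has been measured and on what is new or still open speak of the compounds shown alone.

- compound 1 `CC(C)c1n[nH]c2c(NCc3ccc(-c4ccccn4)cc3)nc(SCC(C)(C)O)nc12` with 507 nM
- compound 2 `CC(C)c1n[nH]c2c(NCc3ccc(-c4ccccn4)cc3)nc(SCCCN(C)C)nc12` with 105 nM

In a functional assay on HT cells (Homo sapiens) for antiproliferative activity, read by fluorescence, with a stated time of 72 h (a higher number here means a weaker inhibitor of growth, a lower number a stronger inhibitor of growth), compound 2 gives 105 nM and so holds the lower of the two numbers. Compound 3 `CC(C)c1n[nH]c2c(NCc3ccc(-c4ccccn4)cc3)nc(SCCNC(=N)N)nc12` differs from compound 2 in one place. The change is a group of 4 heavy atoms (1 carbon, 3 nitrogen; no ring) in place of a group of 4 heavy atoms (3 carbon, 1 nitrogen; no ring), on a saturated chain carbon, two bonds along the chain from a sulfur and the rest of the molecule stays the same. For the measured compounds named here, the only measured step on this chain is a 4.8-fold lower number from compound 1 to compound 2 (0.68 log units; beyond the scatter) and it shows that groups here can shift the number, though it involves a different group. The expected step is a 2.4-fold higher number from compound 2 to compound 3 (0.38 log units; beyond the scatter) and this is smaller than the measured one, with wide uncertainty. For compound 3 the expected value is 250 nM with an estimated range from 70 nM to 800 nM in this assay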

Compound 3, concentration for 50% growth inhibition: 390 nM
Compound 3: the middle estimate sits 1.6-fold (0.19 log units) below what was measured; low and high end bracket the measured number.
By their numbers in this assay, from the lowest: compound 2; then compounds 3 and 1 (each within the scatter of the next).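

In this assay the lower number of compound 2 proves sensitive to what ends the chain: replacing its (dimethylamino)methyl with the group of 1 carbon and 3 nitrogen gives a 3.7-fold higher number from compound 2 to compound 3 (0.57 log units; beyond the scatter) and does not preserve it. Against the hydroxy-bearing chain of compound 1, the same group gives a 1.3-fold lower number from compound 1 to compound 3 (0.11 log units; within the scatter) and so cannot be told apart from it. Nothing available explains either step. Still open, from the compounds shown here alone, is how a primary amine at this chain end would compare, and whether a longer chain carrying the dimethylamino group would move the number further.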